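The compounds below may be only part of what the source reports. "The series", "measured", "known", "first", "only" and "open" are said of these compounds alone.

Measured so far:
compound 1, `O=C(C1CCCCC1)N1CCC(C(=O)N2N=CCC2c2ccccc2)CC1`, 5.4
compound 2, `O=C(c1cscn1)N1CCC(C(=O)N2N=CC[C@H]2c2ccccc2)CC1`, 3

In a physicochemical assay for lipophilicity, read by HPLC, measured as chromatographic lipophilicity, at pH 7.4 (on this read-out higher numbers stand for higher lipophilicity and lower numbers for lower lipophilicity), compound 1 stands highest of the two numbers; compound 2 gives a value well below it, and the gap lies beyond the scatter. Compound 3, `O=C(c1cc[nH]n1)N1CCC(C(=O)N2N=CCC2c2ccccc2)CC1`, has not yet been measured in this assay. It differs from compound 1 in one place: 1H-pyrazol-3-yl in place of cyclohexyl on a carbonyl carbon. Among the compounds with values here, since no step between measured compounds covers this change, the expectation rests on the spread seen between compound 1 and compound 2. A large downward step is expected, a number 2.80 log units lower from compound 1 to compound 3 (beyond the scatter). For compound 3 the estimate in this assay is 2.6, from 1.9 to 3.3.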

Compound 3, distribution coefficient: 2.4
For compound 3 the middle estimate is 0.20 log units above the measured one, within the range that was stated.
By their numbers in this assay, from the lowest: compound 3; then compound 2; then compound 1.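

In this assay, this position on a carbonyl carbon now has its first comparison in one place: a number 3.00 log units lower from compound 1 to compound 3 (beyond the scatter), so the read-out responds strongly to the group held there. The change removes a six-membered non-aromatic ring of carbon only and brings in a five-membered aromatic ring with 2 hetero atoms, 1 hydrogen-bond donor and 1 hydrogen-bond acceptor. Nothing available explains the size of this step.

The compounds shown leave open how much of the step goes with the hydrogen-bond donor and how much with the aromatic ring. A 1-methylpyrazol-3-yl or phenyl group on the same carbonyl carbon would begin to separate the two.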